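Hydroxy added on the aryl ring of compound 2

The source may hold more compounds than are shown below. What is called first, only, known or untested is meant among the compounds shown, and "the series" means these compounds.

Three compounds of the series carry a measured value in a functional assay, with a stated time of 10 min; on this read-out lower numbers stand for stronger inhibition and higher numbers for weaker inhibition. Compound 1 `CN(C)c1ccc(-c2nc(NN)n(C)c(=O)c2C#N)cc1` gives 66 ug/mL. Compound 2 `CCOC(=O)c1cnn(-c2nc(-c3ccccc3O)c(C#N)c(=O)n2C)c1N` gives 58 ug/mL. Compound 3 `Cn1c(NN)nc(-c2ccco2)c(C#N)c1=O` gives 58 ug/mL. Compound 2 stands level with compound 3 at the digits shown, and together they hold the lowest of the three numbers; the gap from compound 2 to compound 1 lies within the scatter, as does the gap to compound 3, so no order among the three can be read from these numbers.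

Compound 4 `CCOC(=O)c1cnn(-c2nc(-c3cccc(O)c3O)c(C#N)c(=O)n2C)c1N` is not yet measured. It differs from compound 2 by hydroxy in place of hydrogen on an aromatic carbon, ortho to a hydroxy group and meta to a large group, so that 2-hydroxyphenyl becomes 2,3-dihydroxyphenyl. Among the compounds with values here, no pair of measured compounds differs in one place, so no measured step shows what such a change does in this assay. Within the data shown here, the three values so far all lie within the scatter of one another despite quite different groups on the shared core, which gives no ground to expect a large move in either direction from one added hydroxy.

The expectation for compound 4 is therefore a number close to that of compound 2, with the step of a 1.1-fold lower number from compound 2 to compound 4 (0.02 log units; within the scatter) expected to stay within the scatter. Compound 4 is estimated at 55 ug/mL, with a range from 25 ug/mL to 120 ug/mL.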

Compound 4, half-maximal inhibitory concentration: 53 ug/mL
Estimate against measurement, compound 4: 1.0-fold (0.02 log units) above; measured number inside the range.
By their numbers in this assay, from the lowest: compounds 4, 2, 3 and 1 (each within the scatter of the next).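

In this assay, placing hydroxy in place of hydrogen on the aromatic carbon ortho to a hydroxy group, so that 2-hydroxyphenyl becomes 2,3-dihydroxyphenyl, gives a 1.1-fold lower number from compound 2 to compound 4 (0.04 log units; within the scatter). Within the data shown here, this is the only measured step between compounds that differ in one place, and it shows that this position of the aryl ring accepts a second hydroxy with no difference that can be read beyond the scatter, something the earlier compounds, which differ in several places, could not show. Nothing available on these compounds bears on what lies behind this result.

One step at one position says nothing about other groups there: an amine, a methoxy group or a carboxylic acid in place of the added hydroxy could still give a number beyond the scatter of compound 2. Also open is the part played by the hydroxy already present in compound 2, since the compounds shown include no plain phenyl partner on the same core with the same aminopyrazole ester.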